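Luciferase inhibition notes: carbamate versus amide on a biaryl pyridine

A few compounds are considered here, and "the series" means these few. Any claim that something is new, unique, unknown or untested is made for them only; others in the source may bear on it.

Measured so far:
compound 1 `O=C(Nc1cccc(-c2ccccc2)n1)c1ccccc1` — 30%
compound 2 `O=C(Nc1ccc(-c2ccccc2)cn1)Oc1ccccc1` — 0%

In an assay on isolated protein (Aquatica lateralis) for inhibition of Luciferin 4-monooxygenase (Luciola lateralis), read by a luciferase reporter, tested at 10 uM (a higher number here means more inhibition at the concentration tested (going by the name of the read-out), a lower number less inhibition), compound 2 gives the lowest of the two numbers; the nearest is compound 1, higher by a margin beyond the scatter. Compound 3 `CCCC(=O)Nc1ccc(-c2ccccc2)cn1` is not yet measured. Compared with compound 2 the change is propyl in place of phenoxy on a carbonyl carbon. Among the compounds with values here, no measured pair shows this change, so its effect is unknown; compound 1 carries a different group on the carbonyl carbon and a differently placed phenyl, so its value cannot be read as a step. Compound 3 is expected to move by a number 10 percentage points higher from compound 2 to compound 3 (within the scatter), a change at or barely beyond the scatter, upward if at all. The estimate for compound 3 is 10%, ranging from 0% to 30%.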

Compound 3, a percentage reported as inhibition, at one concentration (the size of the read-out at that concentration, not a potency): 22%
Beside the measured number, compound 3's estimate is 12 percentage points below it, within the range that was stated.
By their numbers in this assay, from the lowest: compound 2; then compounds 3 and 1 (each within the scatter of the next).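

In this assay, within the data shown here, propyl in place of phenoxy on a carbonyl carbon moves the read-out a number 22 percentage points higher from compound 2 to compound 3 (beyond the scatter) on an otherwise unchanged core, the first readable step. This position therefore responds to the group on the carbonyl carbon, and inhibition at this level does not require the phenoxy group. Nothing available gives a reason for the step.

Whether the oxygen or the aromatic ring of phenoxy accounts for the difference stays open. An ethoxy or a cyclohexyl group on the carbonyl carbon would separate the two, and a longer chain would test how far the propyl result extends.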